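Methyl on the ring amide nitrogen of compound 2

The compounds below may be only part of what the source reports. "The series", "measured", "known", "first", "only" and "open" are said of these compounds alone.

Two compounds of the series have a number in a functional assay on the whole organism (strain Swiss albino) for inhibition, with Mus musculus as the target, in the maximal electroshock model, with a stated time of 2 h, at a dose of 25 mg/kg by the intraperitoneal route; on this read-out lower numbers stand for less inhibition and higher numbers for more inhibition at the one dose given (going by the name of the read-out). Compound 1 `O=C1C(c2ccccc2)CC(c2ccccc2)C(=O)N1c1ccccc1` gives 38.3%. Compound 2 `O=C1NC(=O)C(c2ccccc2Cl)CC1c1ccccc1Cl` gives 58.3%, the higher of the two numbers, and its gap to compound 1 lies beyond the usual scatter. Compound 1 and compound 2 differ in more than one place, so no single step can be read from the pair; only their two values are known.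

Compound 3 `CN1C(=O)C(c2ccccc2Cl)CC(c2ccccc2Cl)C1=O` carries the change (methyl in place of hydrogen on an amide-type nitrogen in a ring). Nothing measured in the series isolates this change: compound 1 bears a phenyl on the ring nitrogen together with unsubstituted phenyl groups on the ring carbons, so its lower value cannot be tied to the nitrogen substituent alone. For the step in this assay from compound 2 to compound 3 a small fall is expected, of a size near the edge of the scatter, with no rise. Compound 3 is estimated at 50%, within 30% to 70%, the expected step being a number 8.3 percentage points lower from compound 2 to compound 3 (within the scatter).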

Compound 3, a percentage reported as inhibition, in the whole organism at one dose (the size of the read-out at that dose, not a potency): 61.7%
Estimate against measurement, compound 3: 11.7 percentage points below; the range from low to high includes it.
By their numbers in this assay, from the lowest: compound 1; then compounds 2 and 3 (each within the scatter of the next).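

In this assay, among these compounds, methyl in place of hydrogen on the amide-type nitrogen in a ring gives a number 3.4 percentage points higher from compound 2 to compound 3 (within the scatter), the first reading of a single change at this position, which the pair of compound 1 and compound 2 could not provide. With the two 2-chlorophenyl groups kept, the amide hydrogen is therefore not required for compound 3 to stay level with compound 2 at this one dose, and the position accepts a methyl without a shift that can be told from the scatter. No measurement in hand bears on why the read-out holds at this position.

As far as these compounds go, whether this nitrogen also accepts something larger or of another kind, such as a propyl chain, a benzyl group or a chain ending in an amine or a carboxylic acid, remains open. Also open, from the compounds shown here alone, is whether the same methyl step would hold on a core without the 2-chlorophenyl groups, and whether the level seen for compound 2 and compound 3 at this single dose and time would extend to other doses or times.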